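From fluoro to bromo on compound 2

This account rests on a few compounds, and the source may have more. Where it says the series, first, only, none or still open, it means among the compounds named here.

Values measured in a functional assay on HeLa cells (Homo sapiens) for inhibition, read by MTT assay, with a stated time of 48 h; on this read-out higher numbers stand for weaker inhibition of growth and lower numbers for stronger inhibition of growth
- Compound 1 `Cn1cc(C2CC(c3ccccc3)=NN2C(=O)c2cccnc2)c2ccccc21` gives > 10000 nM (a limit of the assay, not a number)
- Compound 2 `COc1ccc2c(c1)c(C1CC(c3ccc(F)cc3)=NN1C(=O)c1ccc(OC)nc1)cn2C` gives 410 nM

For the measured compounds named here, compound 2 holds the only actual number in this small set, since the reading for compound 1 is a limit. The next molecule, compound 3 `COc1ccc2c(c1)c(C1CC(c3ccc(Br)cc3)=NN1C(=O)c1ccc(OC)nc1)cn2C`, differs from compound 2 in one place: bromo in place of fluoro on an aromatic carbon. This is bromo in place of fluoro on an aromatic carbon, turning 4-fluorophenyl into 4-bromophenyl.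

Going by the values given here, no measured pair shows what such a swap does, so the expectation starts from compound 2 at 410 nM and assumes no step beyond the scatter, in either direction. The expected size of a 1.0-fold lower number from compound 2 to compound 3 (0.01 log units; within the scatter) is therefore small. In this assay the estimate for compound 3 is 400 nM, with the measurement expected between 130 nM and 1300 nM.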

Compound 3, concentration for 50% growth inhibition: > 10000 nM
Compound 3 gave a limit, no number (the forecaster's own chance of this, stated with the estimate: 3%); middle value at least 25-fold (1.39 log units) away from the limit.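

In this assay, bromo in place of fluoro on this aromatic carbon gives an at least 24-fold higher number from compound 2 to compound 3 (1.38 log units; beyond the scatter). A change of one atom at this position can therefore matter a great deal, and 4-fluorophenyl and 4-bromophenyl cannot be treated as interchangeable here. The size of the step is only a lower bound, as compound 3 gives a limit rather than a number: the limit of > 10000 nM in this assay, at which 2 of the 3 values shown sit.

The compounds shown leave open how chloro, a smaller halogen swap from fluoro, or an amine or a methoxy group would behave at this same position, so no trend across groups can yet be drawn from this single pair. As far as these compounds go, it also remains open whether the same swap would have so large an effect on a different core or with a different group on the amide carbonyl.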